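Changing the ring on the amide carbonyl

The source may hold more compounds than are shown below. What is called first, only, known or untested is meant among the compounds shown, and "the series" means these compounds.

Compound 1, `O=C(Nc1cc(-c2ccccc2)nn1-c1ccccc1)c1ccccc1`: 203 nM
Compound 2, `COc1cccc(C(=O)Nc2cc(-c3ccccc3)nn2-c2ccccc2)c1`: 102 nM

Both compounds share one core and differ only in the ring attached to the carbonyl carbon. In a functional assay on cells for positive allosteric modulation of metabotropic glutamate receptor 5 (Rattus norvegicus), read by calcium flux (a higher number here means that more compound is needed for the effect, a lower number that less compound is needed), compound 2 gives the lowest of the two numbers, but compound 1 lies within the scatter of it, as the step of a 2.0-fold lower number from compound 1 to compound 2 (0.30 log units; within the scatter) shows. Compound 3, `O=C(Nc1cc(-c2ccccc2)nn1-c1ccccc1)c1ccc(Cl)c(Cl)c1`, carries the change (3,4-dichlorophenyl in place of 3-methoxyphenyl on a carbonyl carbon). Among the measured compounds shown here, only one measured step touches this ring, and it stayed within the scatter; nothing measured shows what chlorine on this ring does. Because the step from compound 1 to compound 2 was a 2.0-fold lower number from compound 1 to compound 2 (0.30 log units; within the scatter), the step for compound 3 is expected to be small as well, about a 1.2-fold higher number from compound 2 to compound 3 (0.07 log units; within the scatter). In this assay compound 3 is estimated to give 120 nM, with a likely range from 40 nM to 400 nM.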

Compound 3, half-maximal effective concentration: 13 nM
Beside the measured number, compound 3's estimate is 9.2-fold (0.97 log units) above it; measured number below the stated range.
By their numbers in this assay, from the lowest: compound 3; then compounds 2 and 1 (each within the scatter of the next).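

In this assay, among the compounds shown here, the ring on the carbonyl carbon turns out to matter far more than the one earlier step suggested: 3,4-dichlorophenyl in place of 3-methoxyphenyl gives a clear change (a 7.8-fold lower number from compound 2 to compound 3 (0.89 log units; beyond the scatter)), and in place of plain phenyl a larger one (a 16-fold lower number from compound 1 to compound 3 (1.19 log units; beyond the scatter)). The leaving 3-methoxyphenyl and the entering 3,4-dichlorophenyl have the same count of heavy atoms, so that count alone does not separate them. Nothing at hand explains the result.

The two chlorines enter together, so the compounds shown leave open what a single chlorine on this ring would do. Also open, as far as these compounds go, is how other groups on the ring, such as fluorine, trifluoromethyl or an amine, would compare.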